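Moving from one halogen to two on the benzylidene ring

This account rests on a few compounds, and the source may have more. Where it says the series, first, only, none or still open, it means among the compounds named here.

Going by the values given here, compound 1 `C=CCn1c(=O)/c(=C\c2cccc(F)c2)[nH]c(=O)/c1=C\c1ccccc1OC` is the only member of this small set with a numerical result: in a functional assay on U-937 cells (Homo sapiens) for cytotoxicity, read by CCK-8 assay, with a stated time of 72 h (a higher number here means a weaker inhibitor, a lower number a stronger inhibitor), compound 1 gives 2500 nM. Compound 2 `C=CCn1c(=O)/c(=C\c2ccc(Cl)c(Cl)c2)[nH]c(=O)/c1=C\c1ccccc1OC` was reported in this assay as "not active" (no number reported), without a number. Compound 3 `C=CCn1c(=O)/c(=C\c2ccc(F)c(Br)c2)[nH]c(=O)/c1=C\c1ccccc1OC` carries 3-bromo-4-fluorophenyl in place of 3-fluorophenyl on a double-bonded chain carbon bound to an aromatic carbon. The change brings compound 3 closer in appearance to compound 2, which showed no activity, so a weakening is expected, with a step from compound 1 to compound 3 of roughly a 2.4-fold higher number from compound 1 to compound 3 (0.38 log units; beyond the scatter) in this assay. The estimate for compound 3 is 6000 nM, in a range from 2000 nM to 25000 nM.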

Compound 3, half-maximal inhibitory concentration: "not active" (no number reported)
Compound 3 has no reported number here; the estimate stays without a comparison.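

Going by these compounds alone, compound 3, like compound 2, has no number in this assay, so no step from compound 1 can be read. Nothing shown bears on this result. The compounds shown leave open which change to 3-fluorophenyl accounts for the lost activity.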